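A few compounds are considered here, and "the series" means these few. Any claim that something is new, unique, unknown or untested is made for them only; others in the source may bear on it.

Compound 3 `CN1CCN(c2nc3cc(F)ccc3o2)CC1` holds the highest of the three values in an assay on ileum (strain Hartley) with 5-hydroxytryptamine receptor 3A (Cavia porcellus) as the target (a higher number here means a larger maximal response, a lower number a smaller maximal response), giving 0.64; compound 1 `CN1CCN(c2nc3cc([N+](=O)[O-])ccc3o2)CC1` gives 0.52 and compound 2 `CN1CCN(c2nc3cccc(Cl)c3o2)CC1` gives 0.24. Among the measured compounds shown here, the only single-place step measured is a number 0.12 higher from compound 1 to compound 3 (beyond the scatter). Compound 4 `CN1CCN(c2nc3cc(Br)ccc3o2)CC1` differs from compound 3 by bromo in place of fluoro on an aromatic carbon. For the measured compounds named here, no measured step exchanges one halogen for another; compound 2 carries chloro, but no single-place step connects it to compound 3, so its value and that of compound 3 show only a gap between two compounds. With nothing bearing directly on this change, the expectation for this assay is a step within the scatter or a modest fall, a number 0.090 lower from compound 3 to compound 4 (within the scatter). Compound 4 is therefore estimated at 0.55, within 0.35 to 0.75.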

Compound 4, intrinsic activity: the largest response reached, as a fraction of the reference agonist's: 0.48
Compound 4: the middle estimate sits 0.070 above what was measured; measured number inside the range.
By their numbers in this assay, from the lowest: compound 2; then compounds 4 and 1 (each within the scatter of the next); then compound 3.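

In this assay, bromo in place of fluoro gives a number 0.16 lower from compound 3 to compound 4 (beyond the scatter) and so shows that one halogen exchange at this position can move the maximal response, while bromo in place of nitro gives a number 0.040 lower from compound 1 to compound 4 (within the scatter) and leaves those two groups unresolved. Among the three groups at this position, fluoro alone stands apart. Nothing available accounts for this difference. Going by these compounds, whether an amine or a methoxy group at this position would match fluoro, or match bromo and nitro, remains open.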